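Pyrrole in place of furan on the aryl ring

This account rests on a few compounds, and the source may have more. Where it says the series, first, only, none or still open, it means among the compounds named here.

Measured so far:
compound 1 `c1ccc(-c2cnccn2)c(OCC2=NCCN2)c1` gives 97%
compound 2 `c1coc(-c2ccccc2OCC2=NCCN2)c1` gives 106%

In a functional assay with Alpha-1A adrenergic receptor (Homo sapiens) as the target, read by calcium flux (a lower number here means a smaller maximal response, a higher number a larger maximal response), compound 2 stands highest of the two numbers, but only by a margin within the scatter: the step of a number 9 percentage points higher from compound 1 to compound 2 (within the scatter) does not separate the two compounds. Compound 3 `c1c[nH]c(-c2ccccc2OCC2=NCCN2)c1` is the next step from compound 2. The change is 1H-pyrrol-2-yl in place of furan-2-yl on an aromatic carbon.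

Among the compounds with values here, only one measured step bears on this change, the exchange of one aryl ring for another from compound 1 to compound 2, and it stayed within the scatter. A ring exchange at the same place is therefore expected to leave the maximal response essentially unchanged, so the estimated step of a number 6 percentage points lower from compound 2 to compound 3 (within the scatter) is expected to lie within the scatter. For compound 3 the estimated value is 100%, with an expected range from 85% to 115%.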

Compound 3, largest response reached (reported as maximum), in percent of the reference or control that the assay uses: 99%
Estimate against measurement, compound 3: 1 percentage points above; measured number inside the range.
By their numbers in this assay, from the lowest: compounds 1, 3 and 2 (each within the scatter of the next).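

In this assay the group on the aromatic carbon changes from furan-2-yl, with 1 hydrogen-bond acceptor and 0 hydrogen-bond donors, to 1H-pyrrol-2-yl, with 1 hydrogen-bond donor and 0 hydrogen-bond acceptors, and the outcome is a number 7 percentage points lower from compound 2 to compound 3 (within the scatter) so this exchange of acceptor for donor does not separate the two compounds. Against pyrazin-2-yl the same group gives a number 2 percentage points higher from compound 1 to compound 3 (within the scatter) and the three aromatic rings shown at this place therefore cannot be told apart by their maximal response. Nothing at hand accounts for this insensitivity.

From the compounds shown here alone, all three groups are aromatic rings, so it remains open whether an amine, a carboxylic acid or a longer chain at this place would keep the maximal response. The compounds also leave open whether a plain phenyl ring would do the same.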